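Swapping a hexyl chain for a trifluoromethylphenyl ring

The source may report more compounds than this note shows. Statements on the series, on what has been measured and on what is new or still open speak of the compounds shown alone.

Measured so far:
compound 1 `CCCCc1cn(C(c2ccccc2)c2cc3cc(Br)ccc3nc2OC)nn1`: -2.87%
compound 2 `COc1nc2ccc(Br)cc2cc1C(c1ccccc1)n1cc(-c2ccc(OC(F)(F)F)cc2)nn1`: -2.24%
compound 3 `CCCCCCc1cn(C(c2ccccc2)c2cc3cc(Br)ccc3nc2OC)nn1`: -0.97%

In an ADME assay on HeLa cells (Homo sapiens) for cytotoxicity, read by sulforhodamine B assay, with a stated time of 48 h, tested at 10 uM (on this read-out lower numbers stand for less inhibition and higher numbers for more inhibition at the one concentration tested (going by the name of the read-out)), all three numbers sit within the usual scatter of one another, and compound 3 gives -0.97%. Compound 4 `COc1nc2ccc(Br)cc2cc1C(c1ccccc1)n1cc(-c2ccccc2C(F)(F)F)nn1` differs from compound 3 by 2-(trifluoromethyl)phenyl in place of hexyl on an aromatic carbon. Two earlier steps bear on this, since each trades an alkyl chain for a substituted phenyl ring on the same aromatic carbon or back again: a number 1.3 percentage points higher from compound 2 to compound 3 (within the scatter) and a number 0.6 percentage points higher from compound 1 to compound 2 (within the scatter). Neither moved the read-out beyond the scatter, so for compound 4 no change beyond the scatter is expected, which is the meaning of a number 0.5 percentage points lower from compound 3 to compound 4 (within the scatter). Compound 4 is therefore estimated at -1.5%, in a range from -12% to 9%.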

Compound 4, a percentage reported as inhibition, at one concentration (the size of the read-out at that concentration, not a potency): -1.3%
Compound 4: the middle estimate sits 0.2 percentage points below what was measured; the range from low to high includes it.
By their numbers in this assay, from the lowest: compounds 1, 2, 4 and 3 (each within the scatter of the next).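

Compound 4 places another substituted phenyl ring, 2-(trifluoromethyl)phenyl, on this aromatic carbon, and in this assay there is a number 0.3 percentage points lower from compound 3 to compound 4 (within the scatter) and a number 0.9 percentage points higher from compound 2 to compound 4 (within the scatter) and a number 1.6 percentage points higher from compound 1 to compound 4 (within the scatter). Across these four compounds, the read-out therefore does not separate butyl, hexyl, 4-(trifluoromethoxy)phenyl and 2-(trifluoromethyl)phenyl at this position, whether the group is a chain or a ring. No measured evidence is available to explain this result.

Still open, from the compounds shown here alone, is whether a group of another type here, such as an amine or a carboxylic acid, would give a number beyond the scatter.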